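The source may hold more compounds than are shown below. What is called first, only, known or untested is meant among the compounds shown, and "the series" means these compounds.

Measured compounds:
compound 1 `COC(=O)[C@H](C)[C@H]1CC[C@@](C)(CCC2=C(C)CCCC2(C)C)OO1`; compound 2 `C=C1CCC[C@H]2[C@](C)(CC[C@]3(C)CC[C@H]([C@@H](C)C(=O)O)OO3)[C@@H](C)CC[C@]12C`; compound 3 `C=C1CCCC(C)(C)C1CC[C@@]1(C)CC[C@H]([C@@H](C)C(=O)O)OO1`

In a functional assay on NCI-H23 cells (Homo sapiens) for inhibition (a lower number here means a stronger inhibitor of growth, a higher number a weaker inhibitor of growth), compound 2 gives 2020 nM and compound 3 gives 7610 nM. For compound 1 only a limit of the assay is recorded, > 25000 nM; with one of the three values sitting there, the limit of > 25000 nM in this assay, at which 1 of the 3 values shown sits, marks the edge of what this assay resolves. Among the two numbers, compound 3 stands highest, its nearest neighbour being compound 2, whose number is lower by a margin beyond the scatter. Within the data shown here, no single-change pair among the measured compounds is available, so no measured step can be pointed to.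

Compound 4 `C=C1CCCC(C)(C)C1CC[C@]1(C)CC[C@@H]([C@@H](C)C(=O)O)OO1` is next. Its relation to compound 3 is the two compounds have the same atoms and bonds; at least one stereo element is drawn with a configuration in one of them and without one in the other: 2 of 4 stereo elements differ; a stereocentre at a saturated ring carbon is drawn S in compound 3 and R in compound 4; a stereocentre at a saturated ring carbon is drawn R in compound 3 and S in compound 4. The two compounds are thus diastereomers, with the peroxide-ring stereocentres inverted. Nothing measured here bears on such an inversion, and the direction of the step is open. The step from compound 3 to compound 4 is expected to be small, a 1.1-fold higher number from compound 3 to compound 4 (0.02 log units; within the scatter), with a wide range on either side. Compound 4 is expected to give about 8000 nM in this assay, between 2500 nM and 25000 nM.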

Compound 4, concentration for 50% growth inhibition: > 10000 nM
Compound 4: a limit, no number; the forecaster's own chance of this, stated with the estimate: 25%; at least 1.2-fold (0.09 log units) between middle value and limit.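

In this assay compound 4 gives only a limit, > 10000 nM, and not a number. Inverting both peroxide-ring stereocentres gives an at least 1.3-fold higher number from compound 3 to compound 4 (0.11 log units; that floor lies within the scatter), so this change can now be read for the first time, but only as a floor that does not separate the two compounds. The true size of the step stays unread because the reading ends at a limit: the limit of > 10000 nM in this assay, at which 1 of the 4 values shown sits.

The compounds shown leave open whether inverting only one of the two stereocentres would read the same, and whether the inversion would read alike on the core of compound 2. They also leave open how a primary amide in place of the carboxylic acid would read on either diastereomer.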